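Swapping a Sulfur-Linked Ring for an Oxygen-Linked Ring

The source may report more compounds than this note shows. Statements on the series, on what has been measured and on what is new or still open speak of the compounds shown alone.

Measured compounds in a functional assay on OVCAR-8 cells (Homo sapiens) for inhibition, read by sulforhodamine B assay, with a stated time of 48 h; on this read-out lower numbers stand for stronger inhibition of growth and higher numbers for weaker inhibition of growth:
compound 1 `Nc1cc(N)c2nc(-c3ccccc3)c(NCc3ccc(F)cc3)nc2c1` gives 6030 nM.
compound 2 `COc1ccc(Sc2nc3cc(N)cc(N)c3nc2-c2ccccc2)cc1` gives < 100000 nM, which is a limit of the assay rather than a number.
compound 3 `Nc1cc(N)c2nc(-c3ccccc3)c(Sc3ccc(Cl)c(Cl)c3)nc2c1` gives < 100000 nM, likewise only a limit.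

Compound 3 therefore has no number of its own in this assay; its value sits at the limit of < 100000 nM in this assay, at which 2 of the 3 values shown sit, and compound 2 sits there too. Compound 4 `Nc1cc(N)c2nc(-c3ccccc3)c(Oc3ccc(F)cc3)nc2c1` differs from compound 3 in one place: 4-fluorophenoxy in place of (3,4-dichlorophenyl)sulfanyl on an aromatic carbon. None of the three measured steps has a readable size, since each runs into that limit: a step that the limit leaves unreadable from compound 1 to compound 2, a step that the limit leaves unreadable from compound 1 to compound 3 and a step that the two limits leave unreadable from compound 2 to compound 3. Within the data shown here, the only real number is that of compound 1, whose (4-fluorobenzyl)amino group stands where compound 4 carries 4-fluorophenoxy, and both groups contain a fluorine-bearing ring. With the direction and size of every measured step hidden by the limit, the step that the limit leaves unreadable from compound 3 to compound 4 is expected to lean toward stronger growth inhibition, with wide uncertainty. Compound 4 is estimated at 20000 nM, within a range from 3000 nM to 100000 nM.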

Compound 4, concentration for total growth inhibition: 47900 nM
For compound 4 the middle estimate is 2.4-fold (0.38 log units) below the measured one; low and high end bracket the measured number.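

In this assay, 4-fluorophenoxy in place of (4-fluorobenzyl)amino on this aromatic carbon gives a 7.9-fold higher number from compound 1 to compound 4 (0.90 log units; beyond the scatter), so the oxygen-linked compound inhibits growth more weakly than the nitrogen-linked one, by a step beyond the scatter. Among these compounds, this is the first readable comparison at this position, and it shows that the group held here can shift the read-out even when both groups carry a fluorine-bearing ring. The steps from compound 2 and from compound 3 to compound 4 cannot be read, because both of those compounds sit at a limit of the assay: the limit of < 100000 nM in this assay, at which 2 of the 4 values shown sit.

As far as these compounds go, compound 3 and compound 4 differ in both the linking atom and the groups on the ring, so the effect of oxygen against sulfur alone remains open. From the compounds shown here alone, how a 4-fluorophenylsulfanyl group, a simple amine or a longer chain would read at this position also remains open.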